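A few compounds are considered here, and "the series" means these few. Any claim that something is new, unique, unknown or untested is made for them only; others in the source may bear on it.

In an ADME assay on CHO cells (Cricetulus griseus) for cytotoxicity, read by MTT assay, with a stated time of 24 h (on this read-out lower numbers stand for stronger inhibition and higher numbers for weaker inhibition), compound 1 `CCOS(=O)(=O)/C=C/c1ccc(OCC2=CC[C@@H]3C(C(=O)Nc4ccc(Oc5ccc(-c6ccccc6)cc5)cc4)=CO[C@@H](OC)[C@H]23)cc1` gives > 200000 nM, which is a limit of the assay and not a number. Compound 2 `CCOS(=O)(=O)/C=C/c1ccc(OCC2=CC[C@@H]3C(C(=O)Nc4ccc(Oc5ccc(Br)cc5Cl)cc4)=CO[C@@H](OC)[C@H]23)cc1` gives > 200000 nM, which is likewise only a limit, so its true value cannot be placed. Compound 3 `CCOS(=O)(=O)/C=C/c1ccc(OCC2=CC[C@@H]3C(C(=O)Nc4ccc(Oc5ccc(Br)cc5Cl)cc4)=CO[C@@H](OCc4ccccc4)[C@H]23)cc1` differs from compound 2 by phenyl in place of hydrogen on a saturated chain carbon bound to an oxygen on a saturated carbon, which turns methoxy into benzyloxy. Among the compounds with values here, the only measured change, 4-bromo-2-chlorophenyl in place of 4-phenylphenyl on an oxygen on an aromatic ring, is a step that the two limits leave unreadable from compound 1 to compound 2. It lies at a different place and gives no size to carry over, and the only firm observation is the limit of > 200000 nM in this assay, at which 2 of the 2 values shown sit. The expected a number no higher from compound 2 to compound 3 (the limit leaves the size open) is therefore none beyond the usual scatter, with no direction foreseen. For compound 3 the estimate is 200000 nM, with an expected range of 80000 nM to 400000 nM.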

Compound 3, half-maximal inhibitory concentration: > 200000 nM
Compound 3: no number, only a limit; the forecaster's own chance of this, stated with the estimate: 80%; the middle value sits exactly at the limit.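

No step can be read from compound 2 to compound 3, as both results are limits of the assay and not numbers: the limit of > 200000 nM in this assay, at which 3 of the 3 values shown sit.

The compounds shown leave open where their true values lie in this assay and whether changing methoxy to benzyloxy makes any difference there.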